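Methyl for iodo on the fused core of compound 1

The compounds below may be only part of what the source reports. "The series", "measured", "known", "first", "only" and "open" are said of these compounds alone.

Compound 1 `O=C1NC(c2c[nH]nc2-c2ccccc2)Nc2c(I)cc(Cl)cc21` carries an iodo and a chloro group on its fused core with a phenyl on the pyrazole. In an assay on HEK293 cells for inhibition of transient receptor potential cation channel subfamily M member 2 (Homo sapiens), read by patch clamp, with a stated time of 60 s (a lower number here means a stronger inhibitor, a higher number a weaker inhibitor), compound 1 returned "not determined" (no result reported), so no number stands for it. Compound 2 `Cc1cc(Cl)cc2c1NC(c1c[nH]nc1-c1cccc3ccccc13)NC2=O` bears methyl in place of the iodo and a naphthyl on the pyrazole; in this assay compound 2 gives 4000 nM. Compound 3 `Cc1cc(Br)cc2c1NC(c1c[nH]nc1-c1ccc([N+](=O)[O-])cc1)NC2=O` has methyl and bromo on the core and a nitrophenyl; in this assay compound 3 returned "not determined" (no result reported), again without a number. For the measured compounds named here, compound 1 thus stands without a single value, and compound 3 is the one further entry of that kind; compound 2 is the only anchor with a number.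

Compound 4 `Cc1cc(Cl)cc2c1NC(c1c[nH]nc1-c1ccccc1)NC2=O` differs from compound 1 by methyl in place of iodo on an aromatic carbon. No step between measured compounds is available, and compound 1 has no value, so no size can be derived for this exchange in this assay; on the data shown, no step beyond the scatter is expected in either direction. Compound 4 resembles compound 2 except for the phenyl in place of the naphthyl, so compound 4 is expected to fall near that anchor, with an estimated half-maximal inhibitory concentration of 4000 nM in this assay, in a range from 800 nM to 20000 nM.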

Compound 4, half-maximal inhibitory concentration: 5100 nM
Beside the measured number, compound 4's estimate is 1.3-fold (0.11 log units) below it, and the stated range covers the measured number.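

No new step can be read: in this assay compound 1 gives "not determined" (no result reported) and compound 4 gives 5100 nM, so the exchange of iodo for methyl between compound 1 and compound 4 has no size. No measured evidence bears on this result. The compounds shown leave open how iodo and methyl compare on otherwise identical structures.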